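The compounds below may be only part of what the source reports. "The series", "measured", "known", "first", "only" and "open" are said of these compounds alone.

The shared core carries a phenyl group and a hydroxy acid on the aromatic ring. Compound 1, `O=C(O)c1cc(-n2c(-c3ccccc3)cc3c2CCCC3)ccc1O`, was tested in a functional assay on the whole organism (strain Wistar) for inhibition, with Rattus norvegicus as the target, read by paw edema, with stated times of 30 min and 3 h, at a dose of 200 mg/kg by the oral route; a higher number here means more inhibition at the dose given (going by the name of the read-out), a lower number less inhibition. In this assay compound 1 gives >= 60%, which is a limit of the assay rather than a number (the limit of >= 60% in this assay, at which 1 of the 2 values shown sits). Compound 2, `CC1CCc2c(cc(-c3ccccc3)n2-c2ccc(O)c(C(=O)O)c2)C1`, in this assay gives 40%; this is the only plain number shown among the two compounds measured so far. Between them there is a number at least 20 percentage points lower from compound 1 to compound 2 (beyond the scatter). Compound 3, `CC(C)(C)C1CCc2c(cc(-c3ccccc3)n2-c2ccc(O)c(C(=O)O)c2)C1`, differs from compound 2 in one place: tert-butyl in place of methyl on a saturated ring carbon. Within the data shown here, the only measured step that bears on this change is the one from compound 1 to compound 2, where the same position on the saturated ring carried a methyl group in place of hydrogen and the result fell by at least a modest amount. Growing that group further is expected to give a number 8 percentage points lower from compound 2 to compound 3 (within the scatter), a small downward step that may stay within the scatter. Compound 3 is therefore estimated to give 32% in this assay, with a range from 12% to 55%.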

Compound 3, a percentage reported as inhibition, in the whole organism at one dose (the size of the read-out at that dose, not a potency): 0%
Compound 3: the middle estimate sits 32 percentage points above what was measured; the whole stated range lies above it.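

Going from methyl to tert-butyl on this saturated ring carbon in this assay gives a number 40 percentage points lower from compound 2 to compound 3 (beyond the scatter), so a further change at this position can have a large effect of its own, beyond the first step from hydrogen to methyl. Over the whole change, tert-butyl in place of hydrogen gives a number at least 60 percentage points lower from compound 1 to compound 3 (beyond the scatter), and the three compounds shown now fall in one order, hydrogen, methyl, tert-butyl, with none going against it. Compound 1 stands at a limit and not at a number, so the full length of this span cannot be read: the limit of >= 60% in this assay, at which 1 of the 3 values shown sits.

The compounds shown carry only hydrogen, methyl and tert-butyl at this carbon, all at a single oral dose, so they leave open whether the read-out falls evenly or drops sharply somewhere between methyl and tert-butyl, which an ethyl or isopropyl group there would help to settle. They also leave open whether the fall is tied to carbon groups alone, a question that a hydroxy group or an amine on the same carbon would address.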